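Chlorobenzyl to fluorobenzyl on a thioether series

The compounds below may be only part of what the source reports. "The series", "measured", "known", "first", "only" and "open" are said of these compounds alone.

Measured compounds:
compound 1 `COc1ccc(C2N=C(SCc3ccccc3Cl)NC(C)=C2C(=O)Nc2ccc(F)cc2)cc1OC` gives 2.6%
compound 2 `COc1ccc(C2N=C(SCc3cccc(Cl)c3)NC(C)=C2C(=O)Nc2ccc(F)cc2)cc1OC` gives 2.1%
compound 3 `COc1ccc(C2N=C(SCc3ccc(Cl)cc3)NC(C)=C2C(=O)Nc2ccc(F)cc2)cc1OC` gives 3.1%

All three were read in a functional assay on the whole organism (artery, strain albino) with Rattus norvegicus as the target, with a stated time of 15 min, at a dose of 10 mg/kg by the oral route; a lower number here means less inhibition, a higher number more inhibition at the dose given (going by the name of the read-out). The three numbers sit close together: the steps of a number 0.5 percentage points lower from compound 1 to compound 2 (within the scatter), a number 0.5 percentage points higher from compound 1 to compound 3 (within the scatter) and a number 1 percentage points higher from compound 2 to compound 3 (within the scatter) are each within the scatter, so compound 3 is not set apart from either of the other two, even though its number is the upper one of the three.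

Compound 4 `COc1ccc(C2N=C(SCc3ccc(F)cc3)NC(C)=C2C(=O)Nc2ccc(F)cc2)cc1OC` has not yet been measured. It differs from compound 3 in one place: fluoro in place of chloro on an aromatic carbon. For the measured compounds named here, none of the measured steps changes the halogen itself; they only move the chloro around the ring, and each of them stayed within the scatter. Going by the values given here, no step in the data bears directly on a chloro-to-fluoro exchange at the para position to a large group, so the expectation rests on the flatness of the series as a whole.

For compound 4 the expected value in this assay is 2.8%, with a range from -5% to 11%. The step of a number 0.3 percentage points lower from compound 3 to compound 4 (within the scatter) that this estimate means is expected to stay within the scatter, neither upward nor downward beyond it.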

Compound 4, a percentage reported as inhibition, in the whole organism at one dose (the size of the read-out at that dose, not a potency): 3.6%
Compound 4: middle estimate off by 0.8 percentage points, on the low side; the measured number falls inside the stated range.
By their numbers in this assay, from the lowest: compounds 2, 1, 3 and 4 (each within the scatter of the next).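

In this assay, for the compounds shown here, the halogen itself changes for the first time, and chloro to fluoro on the aromatic carbon para to a large group gives a number 0.5 percentage points higher from compound 3 to compound 4 (within the scatter) and so does not separate the two compounds. The 4-fluorophenyl group also stays level with both other chlorinated isomers, through a number 1.5 percentage points higher from compound 2 to compound 4 (within the scatter) and through a number 1 percentage points higher from compound 1 to compound 4 (within the scatter) as well. Neither the place of the chlorine nor its exchange for fluorine therefore sets any of the four compounds apart at this dose, and nothing on hand explains this flatness.

Open, going by these compounds, is whether an amine or a carboxylic acid in place of the fluoro, or a longer chain in place of the 4-fluorobenzyl group, would carry the number beyond the scatter. Also open, on these data alone, is whether these four compounds would stay level at another dose or time.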